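From 4-chlorophenyl to 3,4-dimethylphenyl on a shared core

The compounds below may be only part of what the source reports. "The series", "measured", "known", "first", "only" and "open" are said of these compounds alone.

In a functional assay on MCF7 cells (Homo sapiens) for inhibition, read by CCK-8 assay, with a stated time of 48 h (on this read-out higher numbers stand for weaker inhibition and lower numbers for stronger inhibition), compound 1 (`COc1cc(-c2ccnc3cc(-c4ccc(F)cc4)nn23)cc(OC)c1OC`) gives 1280 nM, and compound 2 (`COc1cc(-c2ccnc3cc(-c4ccc(Cl)cc4)nn23)cc(OC)c1OC`) gives 2320 nM. Within the data shown here, these are the only two numbers so far, and the step between them, a 1.8-fold higher number from compound 1 to compound 2 (0.26 log units; within the scatter), lies within the scatter, so compound 2 stands level with compound 1. Compound 3 (`COc1cc(-c2ccnc3cc(-c4ccc(C)c(C)c4)nn23)cc(OC)c1OC`) keeps the shared core but carries 3,4-dimethylphenyl in place of 4-chlorophenyl on an aromatic carbon. Among the measured compounds shown here, the step from fluoro to chloro is the only measured one bearing on this change, and it swaps one halogen for another, whereas no measured compound has methyl groups. It therefore offers no direction, and a step beyond the scatter is not expected. The expected change is a 1.2-fold lower number from compound 2 to compound 3 (0.06 log units; within the scatter). For compound 3 the estimated value is 2000 nM, with an expected range of 700 nM to 6000 nM.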

Compound 3, half-maximal inhibitory concentration: 26 nM
Beside the measured number, compound 3's estimate is 77-fold (1.89 log units) above it; the measured number lies below the stated range.
By their numbers in this assay, from the lowest: compound 3; then compounds 1 and 2 (each within the scatter of the next).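

In this assay the move to 3,4-dimethylphenyl brings an 89-fold lower number from compound 2 to compound 3 (1.95 log units; beyond the scatter) where it replaces 4-chlorophenyl and a 49-fold lower number from compound 1 to compound 3 (1.69 log units; beyond the scatter) where it replaces 4-fluorophenyl, so the group on this aromatic carbon can shift the number by far more than the scatter. Among these compounds, the one earlier step, with a 1.8-fold higher number from compound 1 to compound 2 (0.26 log units; within the scatter) for a swap of one halogen for another, gave no sign of such a range at this place. Nothing available here accounts for the size of this drop.

The compounds shown do not tell whether both methyl groups are needed, since none carries a single methyl group on this phenyl ring. They also leave open how a longer chain such as ethyl, or an amine or a methoxy group, would compare in place of the methyl groups.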